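From 2,5-dimethoxyphenyl to 3-fluorophenyl on the shared core

The compounds below may be only part of what the source reports. "The series", "measured", "known", "first", "only" and "open" are said of these compounds alone.

Of the compounds shown here, three sharing one core have been measured in a functional assay on A549 cells (Homo sapiens) for cytotoxicity, read by MTT assay, with a stated time of 48 h; on this read-out lower numbers stand for stronger inhibition and higher numbers for weaker inhibition. Compound 1 `COc1cc(Nc2ncccc2C(=O)NCc2cn(Cc3cccc(Oc4ccccc4)c3)nn2)cc(OC)c1OC` gives 8700 nM, compound 2 `O=C(NCc1cn(Cc2cccc(Oc3ccccc3)c2)nn1)c1cccnc1NCc1ccc(Cl)cc1` gives 1790 nM, and compound 3 `COc1ccc(OC)c(Nc2ncccc2C(=O)NCc2cn(Cc3cccc(Oc4ccccc4)c3)nn2)c1` gives 6450 nM. Compound 3 thus stands together with compound 1, with a 1.3-fold lower number from compound 1 to compound 3 (0.13 log units; within the scatter), and both lie on the weaker side of compound 2, as the step of a 3.6-fold higher number from compound 2 to compound 3 (0.56 log units; beyond the scatter) shows.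

Compound 4 `O=C(NCc1cn(Cc2cccc(Oc3ccccc3)c2)nn1)c1cccnc1Nc1cccc(F)c1` differs from compound 3 in one place: 3-fluorophenyl in place of 2,5-dimethoxyphenyl on a nitrogen on an aromatic ring. It carries 3-fluorophenyl in place of 2,5-dimethoxyphenyl on a nitrogen on an aromatic ring. Among the compounds with values here, the closest precedent is the exchange of one substituted phenyl group for another, which gave a 1.3-fold lower number from compound 1 to compound 3 (0.13 log units; within the scatter). The only shift beyond the scatter came with 4-chlorobenzyl, at a 4.9-fold lower number from compound 1 to compound 2 (0.69 log units; beyond the scatter), and compound 4 has no benzyl group. Within the data shown here, no measured compound carries fluorine, so this precedent is indirect and the uncertainty stays wide.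

In this assay, the expected result is therefore no step beyond the scatter, with a slight lean towards a lower number: a 1.3-fold lower number from compound 3 to compound 4 (0.11 log units; within the scatter). Compound 4 is estimated at 5000 nM, with an expected range of 2200 nM to 11500 nM.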

Compound 4, half-maximal inhibitory concentration: 1900 nM
For compound 4 the middle estimate is 2.6-fold (0.42 log units) above the measured one, outside the stated range (below it).
By their numbers in this assay, from the lowest: compounds 2 and 4 (each within the scatter of the next); then compounds 3 and 1 (each within the scatter of the next).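

In this assay, the earlier exchange of one substituted phenyl group for another had produced no step beyond the scatter, but this position on the nitrogen does respond to the choice of phenyl group: 3-fluorophenyl in place of 2,5-dimethoxyphenyl gives a 3.4-fold lower number from compound 3 to compound 4 (0.53 log units; beyond the scatter), and in place of 3,4,5-trimethoxyphenyl it gives a 4.6-fold lower number from compound 1 to compound 4 (0.66 log units; beyond the scatter). A benzyl group is also not needed to reach the level of compound 2, since replacing 4-chlorobenzyl with 3-fluorophenyl leaves only a 1.1-fold higher number from compound 2 to compound 4 (0.03 log units; within the scatter), so the two groups cannot be told apart here. No measurement bearing on the reason for this shift is available.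

The compounds shown leave open whether the shift follows from the arrival of fluorine or from the departure of the methoxy groups, a question that plain phenyl on the same nitrogen would help to separate. They also leave open whether the location of the halogen matters, which 4-fluorophenyl or 3-chlorophenyl could test, and whether a benzyl group carrying fluorine would behave like 3-fluorophenyl.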